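Trimming the Long Chain from Compound 2

The source may hold more compounds than are shown below. What is called first, only, known or untested is meant among the compounds shown, and "the series" means these compounds.

compound 1 `C/C=C1/[C@H](O[C@@H]2O[C@H](CO)[C@@H](O)[C@H](O)[C@H]2O)OC=C(C(=O)OC)[C@H]1CC(=O)OCCCCCCCCCCCCCCC` gives 380 nM
compound 2 `C/C=C1/[C@H](O[C@@H]2O[C@H](COC(C)=O)[C@@H](OC(C)=O)[C@H](OC(C)=O)[C@H]2OC(C)=O)OC=C(C(=O)OC)[C@H]1CC(=O)OCCCCCCCCCCCCCCC` gives 8000 nM

In a functional assay on HL-60 cells (Homo sapiens) for antiproliferative activity, read by MTT assay, with a stated time of 72 h (on this read-out higher numbers stand for weaker inhibition and lower numbers for stronger inhibition), compound 2 gives 8000 nM as the higher of the two numbers, and its gap to compound 1 lies beyond the usual scatter. Of these two compounds, compound 2 is therefore the weaker inhibitor.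

The next compound to be tested is compound 3 `C/C=C1/[C@H](O[C@@H]2O[C@H](COC(C)=O)[C@@H](OC(C)=O)[C@H](OC(C)=O)[C@H]2OC(C)=O)OC=C(C(=O)OC)[C@H]1CC(=O)OCCC`. Moving to it from compound 2 brings hydrogen in place of dodecyl on a saturated chain carbon, three bonds along the chain from an oxygen next to a carbonyl group in a single place, with hydrogen in place of dodecyl on a saturated chain carbon, three bonds along the chain from an oxygen next to a carbonyl group. Everything else stays the same.

Going by the values given here, no measured pair shows this change alone, so the data give no direct guide to its effect. The expected step is a 1.9-fold higher number from compound 2 to compound 3 (0.27 log units; within the scatter) and it points towards weaker inhibition, but this is a cautious guess. In this assay the estimated value for compound 3 is 15000 nM within an expected range from 5000 nM to 50000 nM as a deliberately wide span.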

Compound 3, half-maximal inhibitory concentration: 10700 nM
The estimate for compound 3 lay 1.4-fold (0.15 log units) above the measured number, within the range that was stated.
By their numbers in this assay, from the lowest: compound 1; then compounds 2 and 3 (each within the scatter of the next).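

In this assay, hydrogen in place of dodecyl on a saturated chain carbon, three bonds along the chain from an oxygen next to a carbonyl group, gives a 1.3-fold higher number from compound 2 to compound 3 (0.13 log units; within the scatter). Going by these compounds alone, this is the first single-place comparison in the set, and it shows that, with everything else held the same, the two compounds cannot be told apart even though the change removes a group of 12 carbon atoms. The finding covers this one pair only, and no measurement shown here offers an explanation for it.

What this change does on the core of compound 1 stays open, as the compounds shown include no counterpart of compound 1 with hydrogen in place of dodecyl. Also open, going by these compounds, is how an amine, a carboxylic acid or a hexyl chain in place of dodecyl would read in this assay, as a single pair at the two extremes of chain size says nothing about the groups that could stand at this place.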